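Four Configurations of One Core, Three Measured, One Expected

The source may report more compounds than this note shows. Statements on the series, on what has been measured and on what is new or still open speak of the compounds shown alone.

compound 1 `C[C@@H]1O[C@H]([C@H]2CCCN2C)C[S@@+]1[O-]` gives < 100000 nM
compound 2 `C[C@H]1O[C@@H]([C@@H]2CCCN2C)C[S@+]1[O-]` gives < 100000 nM
compound 3 `C[C@H]1O[C@@H]([C@H]2CCCN2C)C[S@@+]1[O-]` gives < 100000 nM

In an assay on CHO cells for binding affinity to muscarinic acetylcholine receptor M5 (Homo sapiens) (on this read-out higher numbers stand for weaker inhibition and lower numbers for stronger inhibition), compound 1 stands at a limit of the assay, not at a number. Compound 2 also sits at a limit. Compound 3 sits at a limit as well, so all three values share one floor (the limit of < 100000 nM in this assay, at which 3 of the 3 values shown sit). Compound 4 `C[C@@H]1O[C@H]([C@@H]2CCCN2C)C[S@+]1[O-]` differs from compound 1 only as follows: the two compounds have the same atoms and bonds and differ only in configuration as drawn: 2 of 4 stereo elements differ; a stereocentre at a saturated ring carbon is drawn R in compound 1 and S in compound 4; a stereocentre at a sulfur is drawn R in compound 1 and S in compound 4. For the measured compounds named here, the steps that bear on it, a step that the two limits leave unreadable from compound 1 to compound 2, a step that the two limits leave unreadable from compound 1 to compound 3 and a step that the two limits leave unreadable from compound 2 to compound 3, are all unreadable because the limit of < 100000 nM in this assay, at which 3 of the 3 values shown sit, hides their size. Nothing here separates one configuration from another. Compound 4 is therefore expected near 60000 nM, in the range 8000 nM to 200000 nM. The expected step that the limit leaves unreadable from compound 1 to compound 4 carries no readable direction.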

Compound 4, inhibition constant: < 100000 nM
Compound 4 gave a limit, no number; the forecaster's own chance of this, stated with the estimate: 75%; the middle value lies beyond the limit too.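

In this assay compound 4 gives < 100000 nM, a limit and not a number. For the compounds shown here, no step from compound 1, compound 2 or compound 3 to compound 4 can be read. The compounds shown leave open whether configuration changes the affinity at all.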